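A few compounds are considered here, and "the series" means these few. Any claim that something is new, unique, unknown or untested is made for them only; others in the source may bear on it.

The compounds measured so far:
compound 1, `COC(=O)C1=C(C)N=C(C)/C(=C(\O)OC)C1c1cccc(OC(=O)c2ccccc2)c1`, 6310 nM
compound 2, `COC(=O)C1=C(C)N=C(C)/C(=C(\O)OC)C1c1ccccc1I`, 46.8 nM
compound 3, `COC(=O)C1=C(C)N=C(C)/C(=C(\O)OC)C1c1cc([N+](=O)[O-])ccc1Cl`, 30.2 nM

In a functional assay (muscle tissue) with Cavia porcellus as the target (on this read-out lower numbers stand for an effect already at smaller amounts and higher numbers for an effect only at larger amounts of compound), compound 1 gives the highest of the three numbers. Compound 2 gives 46.8 nM and compound 3 gives 30.2 nM, and both sit far below compound 1, well beyond the scatter. Compound 4, `COC(=O)C1=C(C)N=C(C)/C(=C(\O)OC)C1c1cccc(C#N)c1`, has not yet been measured. It differs from compound 1 in one place: cyano in place of benzoyloxy on an aromatic carbon. Both measured compounds with much lower numbers than compound 1 lack the benzoyloxy group, so the step in this assay is expected to be a large drop, well beyond the scatter, and a 53-fold lower number from compound 1 to compound 4 (1.72 log units; beyond the scatter) is the estimated size. Compound 4 is therefore expected to give 120 nM, with a range from 25 nM to 600 nM.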

Compound 4, half-maximal effective concentration: 34.7 nM
Compound 4: the middle estimate sits 3.5-fold (0.54 log units) above what was measured; the measured number falls inside the stated range.
By their numbers in this assay, from the lowest: compounds 3, 4 and 2 (each within the scatter of the next); then compound 1.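

In this assay, cyano in place of benzoyloxy gives a 180-fold lower number from compound 1 to compound 4 (2.26 log units; beyond the scatter), so at this aromatic carbon on an unchanged core, the high number of compound 1 goes with the benzoyloxy group. The change from 2-iodophenyl to 3-cyanophenyl gives a 1.3-fold lower number from compound 2 to compound 4 (0.13 log units; within the scatter) and so separates these two groups by nothing in this read-out. No evidence is available on why the benzoyloxy step is so large.

From the compounds shown here alone, it remains open whether cyano itself matters or whether losing benzoyloxy is enough. A methoxy group, an amine or a bare hydrogen on the same carbon would separate these two readings.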